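The source may hold more compounds than are shown below. What is called first, only, known or untested is meant among the compounds shown, and "the series" means these compounds.

Compound 1 `CC1(c2ccccc2)CC(=O)N(CC(=O)N2CCN(c3ccc(Cl)cc3)CC2)C1=O` and compound 2 `CC1(c2ccccc2)CC(=O)N(CC(=O)N2CCN(c3cccc(Cl)c3)CC2)C1=O` share one core and differ only in the aryl group on the piperazine nitrogen. In a functional assay on the whole organism (strain CD-1) with Mus musculus as the target, in the maximal electroshock model, with a stated time of 0.5 h (on this read-out lower numbers stand for an effect already at smaller amounts and higher numbers for an effect only at larger amounts of compound), compound 1 is reported as "not active" (no number reported), so no single number stands for it, and its place in this assay cannot be fixed beyond the fact that no effect was found. In this assay compound 2 gives 300 mg/kg. Going by the values given here, nothing more can be said of the pair than what these two results show, since no step between them has been worked out.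

Compound 3 `COc1cccc(N2CCN(C(=O)CN3C(=O)CC(C)(c4ccccc4)C3=O)CC2)c1` has not yet been tested in this assay. Set against compound 1, it carries 3-methoxyphenyl in place of 4-chlorophenyl on an amine nitrogen in a ring. Among the compounds with values here, with compound 1 lacking a number, no step from compound 1 to compound 3 can be stated, and the direction of the change rests only on what compound 2 shows at its own dose. On that basis compound 3 is expected to be weak in this assay, with an estimated minimum effective dose of 300 mg/kg, in the range from 100 mg/kg to 1000 mg/kg, and a real chance that it, too, will be reported without a number.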

Compound 3, minimum effective dose: "not active" (no number reported)
The entry for compound 3 holds no number; no gap can be computed for the estimate.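

In this assay, going by these compounds alone, compound 3 is reported as "not active" (no number reported), and compound 1 likewise gives "not active" (no number reported), so no step from compound 1 to compound 3 can be read. The compounds shown leave open whether compound 1 and compound 3 differ at all in this assay. No supporting measurement bears on this result.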